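Replacing cyano with methyl at a clearance limit

The source may hold more compounds than are shown below. What is called first, only, known or untested is meant among the compounds shown, and "the series" means these compounds.

In an ADME assay on microsomes from liver (Homo sapiens) for metabolic stability (on this read-out higher numbers stand for fast clearance and lower numbers for slow clearance), compound 3 `CCCC(Oc1ccc(-n2cc(C#N)cn2)cc1)c1ccc(C(=O)NCCC(=O)O)cc1` gives < 8 mL/min/kg, which is a limit and not a number. Compound 1 `CCCC(Oc1ccc(-n2cc(OC)cn2)cc1)c1ccc(C(=O)NCCC(=O)O)cc1` gives < 8 mL/min/kg, which is also a limit. Among the compounds with values here, compound 2 `CCCC(Oc1ccc(-n2cc3ccccc3n2)cc1)c1ccc(C(=O)NCCC(=O)O)cc1` gives 44 mL/min/kg, the one measured number so far.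

Compound 4 `CCCC(Oc1ccc(-n2cc(C)cn2)cc1)c1ccc(C(=O)NCCC(=O)O)cc1` is still to be measured. It differs from compound 3 in one place: methyl in place of cyano on an aromatic carbon. This is methyl in place of cyano on an aromatic carbon, so that 4-cyano-1H-pyrazol-1-yl becomes 4-methyl-1H-pyrazol-1-yl.

The closest measured change, cyano in place of methoxy, gives a step that the two limits leave unreadable from compound 1 to compound 3, so it sets no size. The two readable steps both involve 2H-indazol-2-yl, which compound 4 does not carry: an at least 5.5-fold higher number from compound 1 to compound 2 (0.74 log units; beyond the scatter) and an at least 5.5-fold lower number from compound 2 to compound 3 (0.74 log units; beyond the scatter). Compound 4 keeps a 4-substituted 1H-pyrazol-1-yl, and the two compounds of that kind stand at the limit of < 8 mL/min/kg in this assay, at which 2 of the 3 values shown sit. On that basis, the estimated step, an at least 1.2-fold higher number from compound 3 to compound 4 (0.09 log units; that floor lies within the scatter), is expected to be small, with a slight rise the likelier direction. For compound 4 the expected clearance is 10 mL/min/kg, with an estimated range from 6 mL/min/kg to 20 mL/min/kg.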

Compound 4, clearance: 16 mL/min/kg
Estimate against measurement, compound 4: 1.6-fold (0.20 log units) below, and the stated range covers the measured number.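

In this assay, within the data shown here, compound 4 is the first compound with a 4-substituted 1H-pyrazol-1-yl to give a number rather than a limit, so this position, two ring bonds from the ring nitrogen, now has a readable value. Methyl in place of cyano gives an at least 2.0-fold higher number from compound 3 to compound 4 (0.30 log units; that floor lies within the scatter), and methyl in place of methoxy gives an at least 2.0-fold higher number from compound 1 to compound 4 (0.30 log units; that floor lies within the scatter); each figure is only a floor, and neither floor clears the scatter by itself. Among these compounds, the change from 2H-indazol-2-yl to 4-methyl-1H-pyrazol-1-yl gives a 2.8-fold lower number from compound 2 to compound 4 (0.44 log units; beyond the scatter), the first step in this set with a true number at both ends and so the first whose full size can be read.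

The true distance from compound 4 to compound 1 or compound 3 stays unknown, and the order of methoxy and cyano cannot be read, because both of those compounds rest at a limit: the limit of < 8 mL/min/kg in this assay, at which 2 of the 4 values shown sit.

Going by these compounds, what an amine, a chlorine atom or an ethyl group would give at this position remains open, as does how far clearance would go with a longer chain there.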